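Isopropoxy in place of bromo on compound 1

The source may hold more compounds than are shown below. What is called first, only, known or untested is meant among the compounds shown, and "the series" means these compounds.

Among the compounds with values here, in a functional assay on KB cells (Homo sapiens) for antiproliferative activity, read by sulforhodamine B assay, with a stated time of 72 h (a higher number here means a weaker inhibitor, a lower number a stronger inhibitor), compound 1 `O=C(/C=C/c1csc2ccccc12)c1cc(Br)ccc1O` gives 760 nM, the lower of the two numbers measured so far. Compound 2 `O=C(/C=C/c1csc2ccccc12)c1cc(Br)cc(Br)c1O` gives 4800 nM. Compound 3 `CC(C)Oc1ccc(O)c(C(=O)/C=C/c2csc3ccccc23)c1` keeps the core of compound 1 but has isopropoxy in place of bromo on an aromatic carbon, para to a hydroxy group: isopropoxy in place of bromo on an aromatic carbon.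

Within the data shown here, no measured compound carries isopropoxy. Among the measured compounds shown here, the only measured step is a 6.3-fold higher number from compound 1 to compound 2 (0.80 log units; beyond the scatter), with bromo in place of hydrogen on a different aromatic carbon, so it offers only a rough guide to size. A modest step towards a higher number is therefore expected in this assay, although the direction remains uncertain. The expected step is a 2.0-fold higher number from compound 1 to compound 3 (0.30 log units; within the scatter). For compound 3 the estimated value is 1500 nM, with an expected range of 400 nM to 6000 nM.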

Compound 3, half-maximal inhibitory concentration: 10000 nM
Compound 3: the middle estimate sits 6.7-fold (0.82 log units) below what was measured, outside the stated range (above it).
By their numbers in this assay, from the lowest: compound 1; then compound 2; then compound 3.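

In this assay, isopropoxy in place of bromo on the aromatic carbon para to a hydroxy group gives a 13-fold higher number from compound 1 to compound 3 (1.12 log units; beyond the scatter), and this is the only reading at this position among the compounds shown. The earlier step added a bromo on a different aromatic carbon, so this step adds that the carbon para to the hydroxy group also responds to change, and that bromo and isopropoxy are not interchangeable there in this series. No available data bear on the reason for this large step.

Going by these compounds, whether the rise belongs to isopropoxy as a whole or to any oxygen-linked group on this carbon stays open. A methoxy, a chloro or a dimethylamino group at the same place, on the core of compound 1, would help to separate these readings.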